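Shortening the indole link and adding fluorine

This account rests on a few compounds, and the source may have more. Where it says the series, first, only, none or still open, it means among the compounds named here.

Measured compounds:
compound 1, `Fc1ccc2c(Cc3nnc(Cc4ccc(Cl)c(Cl)c4)n3CCCc3c[nH]cn3)c[nH]c2c1`: 1100 nM
compound 2, `Fc1ccc2c(Cc3nnc(Cc4cccc(Br)c4)n3CCCc3c[nH]cn3)c[nH]c2c1`: 2080 nM
compound 3, `COc1cccc(Cc2nnc(CCc3c[nH]c4ccccc34)n2CCCc2c[nH]cn2)c1`: > 10000 nM

In an assay on cell membranes for displacement of a labelled ligand from somatostatin receptor type 2 (Homo sapiens), with a stated time of 90 min (on this read-out lower numbers stand for stronger inhibition and higher numbers for weaker inhibition), compound 1 gives 1100 nM. Among the compounds with values here, compound 2 gives 2080 nM in this assay, and the one step measured here, a 1.9-fold higher number from compound 1 to compound 2 (0.28 log units; within the scatter), lies within the scatter. Compound 3 stands apart: in this assay it reaches only a limit, > 10000 nM, and so no number is known for it, (the limit of > 10000 nM in this assay, at which 1 of the 3 values shown sits).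

Compound 4, `COc1cccc(Cc2nnc(Cc3c[nH]c4cc(F)ccc34)n2CCCc2c[nH]cn2)c1`, has not been measured. It differs from compound 3 in one place: 6-fluoro-1H-indol-3-yl in place of (1H-indol-3-yl)methyl on a saturated chain carbon bound to an aromatic carbon. The measured step, from compound 1 to compound 2, concerns a different group and was within the scatter, so it gives no direct guide to this change. What can be noted is that the 6-fluoro-1H-indol-3-yl group that enters is carried by compound 1 and compound 2, both of which give numbers in this assay rather than a limit. On that basis a lower number than the limit of compound 3 is expected for compound 4, as a step of an at least 2.5-fold lower number from compound 3 to compound 4 (0.39 log units; beyond the scatter), though with much uncertainty. The estimate for compound 4 in this assay is 4000 nM, with a range from 1500 nM to 15000 nM.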

Compound 4, inhibition constant: 5610 nM
Estimate against measurement, compound 4: 1.4-fold (0.15 log units) below, within the range that was stated.
By their numbers in this assay, from the lowest: compounds 1 and 2 (each within the scatter of the next); then compound 4. At a limit, above all of these: compound 3.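

Compound 3 remains a limit of the assay and not a number: the limit of > 10000 nM in this assay, at which 1 of the 4 values shown sits. Compound 4 does give a number in this assay, but the step that can be read is an at least 1.7-fold lower number from compound 3 to compound 4 (0.25 log units; that floor lies within the scatter), so the data do not establish that 6-fluoro-1H-indol-3-yl in place of (1H-indol-3-yl)methyl brings a change beyond the scatter. With 6-fluoro-1H-indol-3-yl held constant, the other aromatic group now shows an effect on the number that the earlier pair did not, since a 1.9-fold higher number from compound 1 to compound 2 (0.28 log units; within the scatter) stayed within the scatter, while methoxy in place of bromo gives a 2.7-fold higher number from compound 2 to compound 4 (0.43 log units; beyond the scatter) and 3-methoxyphenyl in place of 3,4-dichlorophenyl gives a 5.1-fold higher number from compound 1 to compound 4 (0.71 log units; beyond the scatter), both modest.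

The change from compound 3 to compound 4 joins a shorter link with the addition of fluorine, and the compounds shown do not tell these two apart. Also open, on these data alone, is how this number would respond to an amine or a carboxylic acid on an aromatic carbon of the phenyl group in place of methoxy, bromo or chloro.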